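The source may hold more compounds than are shown below. What is called first, only, known or untested is meant among the compounds shown, and "the series" means these compounds.

Compound 1 `COc1ccc(-c2cc3ccc(OCCCCn4cc(CNC(=O)CCCCC5CCSS5)nn4)cc3oc2=O)cc1`: 55.3%
Compound 2 `O=C(CCCCC1CCSS1)NCc1cn(CCCCOc2ccc3cc(-c4ccc(Cl)cc4)c(=O)oc3c2)nn1`: 74.9%

Among the compounds with values here, in a functional assay on PC-12 cells (Rattus norvegicus) for cytotoxicity, read by MTT assay, with stated times of 3 h and 2 h, tested at 50 uM (on this read-out lower numbers stand for a weaker effect and higher numbers for a stronger effect at the one concentration tested), compound 2 stands highest of the two numbers measured, the single gap being a number 19.6 percentage points higher from compound 1 to compound 2 (beyond the scatter). Compound 3 `O=C(CCCCC1CCSS1)NCc1cn(CCCCOc2ccc3cc(-c4ccc(Cl)c(Cl)c4)c(=O)oc3c2)nn1` differs from compound 2 in one place: chloro in place of hydrogen on an aromatic carbon, so that the 4-chlorophenyl becomes 3,4-dichlorophenyl. Within the data shown here, the only measured step, chloro in place of methoxy, is a different kind of change and bears on this one only loosely; no measured pair shows chloro in place of hydrogen. A step of a number 3.1 percentage points higher from compound 2 to compound 3 (within the scatter) is therefore expected, which lies within the scatter. Compound 3 is estimated at 78%, in the range 64% to 90%.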

Compound 3, a percentage reported as activity, at one concentration (the size of the read-out at that concentration, not a potency): 69.5%
The estimate for compound 3 lay 8.5 percentage points above the measured number, and the stated range covers the measured number.
By their numbers in this assay, from the lowest: compound 1; then compounds 3 and 2 (each within the scatter of the next).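

In this assay, adding a second chloro ortho to the first, which turns 4-chlorophenyl into 3,4-dichlorophenyl, gives a number 5.4 percentage points lower from compound 2 to compound 3 (within the scatter), so this added atom shifts the read-out by no more than the scatter. Replacing 4-methoxyphenyl with 3,4-dichlorophenyl gives a number 14.2 percentage points higher from compound 1 to compound 3 (beyond the scatter), so the gain seen on leaving the methoxy-bearing ring persists with the second chloro present. Nothing at hand accounts for either step. From the compounds shown here alone, whether a methyl group, a hydroxyl group or an amine at this same position would also stay within the scatter remains open.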